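Compound 3: lengthening the methyl to pentyl

The source may hold more compounds than are shown below. What is called first, only, known or untested is meant among the compounds shown, and "the series" means these compounds.

- compound 1 `Cc1cc(N2CC[C@@H](C)[C@@H](N(C)c3ncnc4[nH]ccc34)C2)n2nc(SCc3ccc(Cl)cc3)nc2n1`: 18400 nM
- compound 2 `Cc1nc2nc(SCc3ccc(Cl)cc3)nn2c(N2CC[C@@H](C)[C@@H](N(C)c3ncnc4[nH]ccc34)C2)c1C`: > 100000 nM
- compound 3 `CCCCCc1c(C)nc2nc(SCc3ccc(Cl)cc3)nn2c1N1CC[C@@H](C)[C@@H](N(C)c2ncnc3[nH]ccc23)C1`: not yet measured

All values come from a functional assay on HGC-27 cells (Homo sapiens) for inhibition, read by MTT assay, with a stated time of 72 h; on this read-out higher numbers stand for weaker inhibition and lower numbers for stronger inhibition. In this assay compound 2 gives > 100000 nM, which is a limit of the assay and not a number. Compound 3 differs by butyl in place of hydrogen on a saturated chain carbon bound to an aromatic carbon, or methyl to pentyl. Going by the values given here, one measured step bears on this: an at least 5.4-fold higher number from compound 1 to compound 2 (0.73 log units; beyond the scatter), for methyl in place of hydrogen on an aromatic carbon. The methyl that entered there is the one lengthened here. That single step, itself bounded by a limit, fixes no firm size, so only a modest move towards lower numbers is expected, and a further report at the limit remains plausible. The expected step is an at least 1.6-fold lower number from compound 2 to compound 3 (0.22 log units; that floor lies within the scatter). For compound 3 the estimated value is 60000 nM, with an expected range of 15000 nM to 150000 nM.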

Compound 3, half-maximal inhibitory concentration: > 100000 nM
Compound 3: no number, only a limit; the forecaster's own chance of this, stated with the estimate: 45%; at least 1.6-fold (0.22 log units) between middle value and limit.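

In this assay compound 3 gives > 100000 nM, which is a limit of the assay and not a number. Introducing the pentyl chain gives an at least 5.4-fold higher number from compound 1 to compound 3 (0.73 log units; beyond the scatter), so at this position the longer chain, like the methyl of compound 2, does not restore the value of compound 1. The step from compound 2 to compound 3 cannot be read because both results are limits: the limit of > 100000 nM in this assay, at which 2 of the 3 values shown sit.

On these data alone, whether lengthening methyl to pentyl changes inhibition at all remains open, since neither compound 2 nor compound 3 has a number. Also open, as far as these compounds go, is whether a different group at this position, such as an amine or a carboxylic acid, would give a value closer to that of compound 1.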